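The source may hold more compounds than are shown below. What is called first, only, known or untested is meant among the compounds shown, and "the series" means these compounds.

Measured compounds in an ADME assay on Vero cells (Chlorocebus sabaeus) for cytotoxicity, read by resazurin assay, with a stated time of 3 days; on this read-out lower numbers stand for stronger inhibition and higher numbers for weaker inhibition:

- compound 1 `CCCc1ccc(C(=O)Nc2cc3nc(C4CCCCC4)[nH]c3cc2N(CC)CC)cc1`: "not determined" (no result reported)
- compound 2 `CCN(CC)c1cc2[nH]c(C3CCCCC3)nc2cc1NC(=O)c1ccc(OC(F)(F)F)cc1`: > 100 ug/mL
- compound 3 `CCOCCOC(=O)Nc1cc2nc(C3CCCCC3)[nH]c2cc1N1CCCC1`: > 100 ug/mL

Compound 2 gives only a limit in this assay, > 100 ug/mL, not a number. Compound 3 likewise gives only a limit, > 100 ug/mL. Compound 1 has no result in this assay. Among the measured compounds shown here, compound 2 therefore stands at the limit of > 100 ug/mL in this assay, at which 2 of the 3 values shown sit, with one neighbour at the same limit and one neighbour without a value; no step between measured compounds can be read from these three.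

Compound 4 `CCN(CC)c1cc2[nH]c(C3CCCCC3)nc2cc1NC(=O)c1cnccn1` is not yet measured in this assay. It differs from compound 2 in one place: pyrazin-2-yl in place of 4-(trifluoromethoxy)phenyl on a carbonyl carbon.

For the measured compounds named here, no measured step bears on this change, so the expectation rests on compound 2 alone. From compound 2 to compound 4 the step in this assay is expected to be none beyond the scatter, a number no higher from compound 2 to compound 4 (the limit leaves the size open), and compound 4 is most likely to return a limit rather than a number. Compound 4 is estimated at 100 ug/mL, with a range from 40 ug/mL to 300 ug/mL.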

Compound 4, half-maximal inhibitory concentration: > 100 ug/mL
Compound 4 gave a limit, no number; the forecaster's own chance of this, stated with the estimate: 75%; the middle value sits exactly at the limit.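

In this assay compound 4 gives only a limit, > 100 ug/mL, not a number. Compound 2 also gives only a limit, so no step can be read between compound 2 and compound 4. Both sit at the same place in the series: the limit of > 100 ug/mL in this assay, at which 3 of the 4 values shown sit. The compounds shown leave open whether pyrazin-2-yl in place of 4-(trifluoromethoxy)phenyl on a carbonyl carbon changes the read-out at all.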